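Methoxy to hydroxy on a cytotoxicity series

This account rests on a few compounds, and the source may have more. Where it says the series, first, only, none or still open, it means among the compounds named here.

Of the compounds shown here, three have been tested in a functional assay on A549 cells (Homo sapiens) for cytotoxicity, read by sulforhodamine B assay, with a stated time of 48 h, tested at 100 nM; a lower number here means a stronger effect, a higher number a weaker effect of the compound at the concentration tested. Compound 1, `COc1cc(C)cc(-c2c(-c3ccnc(-c4ccc(N(C)C)cc4)c3)cnn2CC#N)c1`, gives 10%. Compound 2, `COc1cc(C)cc(-c2nn(CC#N)cc2-c2ccnc(-c3ccc(N(C)C)cc3)c2)c1`, gives 36%, the second highest of the three numbers: its nearest neighbour is compound 1, whose number lies lower by more than the usual scatter, and its furthest is compound 3, `COc1cc(C)cc(-c2nn(CC#N)cc2-c2ccc(-c3cccc(C(C)=O)c3)nc2)c1`, which gives 91%, a number higher by well more than the scatter. Since a lower number means a stronger effect, compound 2 sits between a clearly stronger and a clearly weaker compound.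

The next compound, compound 4, `Cc1cc(O)cc(-c2nn(CC#N)cc2-c2ccnc(-c3ccc(N(C)C)cc3)c2)c1`, differs from compound 2 in one place: hydrogen in place of methyl on an oxygen on an aromatic ring. For the measured compounds named here, no two compounds already measured differ in exactly this way, so there is nothing in these data that shows how big such a change turns out in this assay. The change is small, a single carbon, and the expectation is a step from compound 2 to compound 4 that stays within or only just beyond the scatter, with no firm direction, as a number 9 percentage points higher from compound 2 to compound 4 (within the scatter) expresses. Compound 4 is therefore expected to give 45% in this assay, within a range from 20% to 75%.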

Compound 4, a percentage reported as activity, at one concentration (the size of the read-out at that concentration, not a potency): 95%
Compound 4: middle estimate off by 50 percentage points, on the low side, and the stated range ends below it.
By their numbers in this assay, from the lowest: compound 1; then compound 2; then compounds 3 and 4 (each within the scatter of the next).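

In this assay the change from methoxy to hydroxy turns out large, with a number a number 59 percentage points higher from compound 2 to compound 4 (beyond the scatter), which means a much weaker effect at the concentration tested. Removing a single methyl from this oxygen on the 3-methoxy-5-methylphenyl group is therefore enough to change the outcome, so this position is sensitive even to a very small edit. Nothing shown here explains why the step is so large.

As far as these compounds go, what remains open is whether the methyl itself matters or whether other groups at this position would keep the effect of compound 2, such as an ethoxy group, a longer alkoxy chain or an amine. It is also unknown whether the same change would have a similar effect on compound 1, which has the stronger effect of the two.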